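From nitro to amino: compound 3 and compound 4

This account rests on a few compounds, and the source may have more. Where it says the series, first, only, none or still open, it means among the compounds named here.

In a functional assay on NCI-H460 cells (Homo sapiens) for positive allosteric modulation, read by MTT assay, with stated times of 2 h and 72 h, tested at 3 uM (a lower number here means a stronger inhibitor, a higher number a weaker inhibitor), the measured compounds read:
compound 1 `COc1cccc(-n2nnc(-c3ccccc3NC(=O)c3ccc(N)cc3)n2)c1` – 212 nM
compound 2 `COc1cccc(-n2nnc(-c3ccccc3NC(=O)c3ccc(NC(C)=O)cc3)n2)c1` – 554 nM
compound 3 `COc1cccc(-n2nnc(-c3ccccc3NC(=O)Nc3ccc([N+](=O)[O-])cc3)n2)c1` – 190 nM

Compound 3 stands level with compound 1 (a 1.1-fold lower number from compound 1 to compound 3 (0.05 log units; within the scatter)) and apart from compound 2 (a 2.9-fold lower number from compound 2 to compound 3 (0.46 log units; beyond the scatter)). Compound 4 `COc1cccc(-n2nnc(-c3ccccc3NC(=O)Nc3ccc(N)cc3)n2)c1` carries amino in place of nitro on an aromatic carbon. Among the measured compounds shown here, no measured step isolates this change. The closest evidence is the exchange of 4-aminophenyl for (4-nitrophenyl)amino on a carbonyl carbon (a 1.1-fold lower number from compound 1 to compound 3 (0.05 log units; within the scatter)). The acetyl step on a nitrogen (a 2.6-fold higher number from compound 1 to compound 2 (0.42 log units; beyond the scatter)) is a different change and bears only loosely. In this assay the expected step stays within the scatter (a 1.2-fold higher number from compound 3 to compound 4 (0.08 log units; within the scatter)). For compound 4 the estimated value is 230 nM within an expected range of 90 nM to 580 nM.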

Compound 4, half-maximal inhibitory concentration: 216 nM
Compound 4: middle estimate off by 1.1-fold (0.03 log units), on the high side, and the stated range covers the measured number.
By their numbers in this assay, from the lowest: compounds 3, 1 and 4 (each within the scatter of the next); then compound 2.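

In this assay, among the compounds shown here, amino in place of nitro on an aromatic carbon, para to a large group, gives the first direct reading of this change, and it stays within the scatter (a 1.1-fold higher number from compound 3 to compound 4 (0.06 log units; within the scatter)). (4-Aminophenyl)amino in place of 4-aminophenyl on the carbonyl carbon also stays within the scatter (a 1.0-fold higher number from compound 1 to compound 4 (0.01 log units; within the scatter)), whereas the same group in place of 4-acetamidophenyl gives a modest step beyond it (a 2.6-fold lower number from compound 2 to compound 4 (0.41 log units; beyond the scatter)). No available data explain these readings.

Going by these compounds, a carboxylic acid or a dimethylamino group on the same aromatic carbon remains open. So does an acetyl on the amino nitrogen of compound 4.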